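Ether chain in place of the alkyne on the cyclobutyl side

This account rests on a few compounds, and the source may have more. Where it says the series, first, only, none or still open, it means among the compounds named here.

Values in an assay on isolated protein for agonist activity at prostaglandin E2 receptor EP3 subtype (Homo sapiens); a lower number here means that less compound is needed, a higher number that more compound is needed for the effect:
compound 1 `CC(C)(C)CCC1([C@H](O)/C=C/[C@H]2COC(=O)N2CCSc2nc(C(=O)O)cs2)CCC1`: 6.7 nM
compound 2 `CC(C)(CCCCF)[C@H](O)/C=C/[C@H]1COC(=O)N1CCSc1nc(C(=O)O)cs1`: 4.7 nM
compound 3 `CC#CCC1([C@H](O)/C=C/[C@H]2COC(=O)N2CCSc2nc(C(=O)O)cs2)CCC1`: 18 nM

Compound 3 stands highest of the three numbers in this assay. Compound 4 `CCOCCC1([C@H](O)/C=C/[C@H]2COC(=O)N2CCSc2nc(C(=O)O)cs2)CCC1` carries ethoxymethyl in place of prop-1-yn-1-yl on a saturated chain carbon bound to a saturated ring carbon. Among the compounds with values here, two measured steps bear on this position, both ending in the alkyne of compound 3: a 2.7-fold higher number from compound 1 to compound 3 (0.43 log units; beyond the scatter) and a 3.8-fold higher number from compound 2 to compound 3 (0.58 log units; beyond the scatter). Within the data shown here, neither involves an ether oxygen, and no measured pair contains one, so the direction of the new step rests only on the alkyne giving the highest number of the three. A modest move back toward compound 1 and compound 2 is expected rather than a large one; for compound 4 the expected step is a 1.5-fold lower number from compound 3 to compound 4 (0.18 log units; within the scatter). Compound 4 is estimated at 12 nM, with a range from 4 nM to 40 nM.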

Compound 4, half-maximal effective concentration: 2610 nM
Estimate against measurement, compound 4: 220-fold (2.34 log units) below; measured number outside the range, above it.
By their numbers in this assay, from the lowest: compounds 2 and 1 (each within the scatter of the next); then compound 3; then compound 4.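

In this assay the 1-(2-ethoxyethyl)cyclobutyl chain costs far more than any earlier change, with a 150-fold higher number from compound 3 to compound 4 (2.16 log units; beyond the scatter) and a 390-fold higher number from compound 1 to compound 4 (2.59 log units; beyond the scatter) and also a 560-fold higher number from compound 2 to compound 4 (2.74 log units; beyond the scatter). The chain carbon bound to a saturated ring carbon therefore carries a sharp sensitivity that the all-carbon neopentyl and prop-1-yn-1-yl groups gave no sign of, with ethoxy in place of tert-butyl enough to produce it. Nothing measured here explains the loss.

From the compounds shown here alone, whether the loss follows the oxygen itself or its place in the chain stays open. A 3-methoxypropyl chain would help separate the two.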